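A Methyl on the Furan of a Hydroxamic Acid

A few compounds are considered here, and "the series" means these few. Any claim that something is new, unique, unknown or untested is made for them only; others in the source may bear on it.

In an assay on Sf9 cells for inhibition of protein deacetylase HDAC6 (Homo sapiens), read by fluorescence, with a stated time of 40 min, tested at 100 nM (on this read-out higher numbers stand for more inhibition at the one concentration tested (going by the name of the read-out) and lower numbers for less inhibition), compound 1 `O=C(NO)c1ccc(NCc2nc(-c3ccco3)nn2-c2ccccc2)cc1` gives 59.9%, the higher of the two measured numbers. Compound 2 `NNC(=O)c1ccc(NCc2nc(-c3ccccc3)nn2-c2ccccc2)cc1`, which differs from it in two places, gives 10%, a number far below that of compound 1 and beyond the usual scatter. Compound 3 `Cc1ccc(-c2nc(CNc3ccc(C(=O)NO)cc3)n(-c3ccccc3)n2)o1` differs from compound 1 in one place: methyl in place of hydrogen on an aromatic carbon. For the measured compounds named here, no measured pair shows the effect of such a change, so only a small step is expected, a number 0.1 percentage points higher from compound 1 to compound 3 (within the scatter), not beyond the scatter. Compound 3 is expected to give about 60%, within a range from 42% to 78%.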

Compound 3, a percentage reported as inhibition, at one concentration (the size of the read-out at that concentration, not a potency): 60.7%
Compound 3: the middle estimate sits 0.7 percentage points below what was measured, within the range that was stated.
By their numbers in this assay, from the lowest: compound 2; then compounds 1 and 3 (each within the scatter of the next).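

In this assay, for the compounds shown here, the change from furan-2-yl to 5-methylfuran-2-yl, on the carbon next to the ring oxygen, gives a number 0.8 percentage points higher from compound 1 to compound 3 (within the scatter), the first comparison here between compounds that differ in one place. At this one concentration, then, the read-out does not separate compound 1 from compound 3 once a methyl sits at this position. No measurement at hand offers an explanation for this result.

As far as these compounds go, whether a larger or different group on this carbon, such as an ethyl chain, an amine or a carboxylic acid, would keep the number at this level remains open. So does whether compound 1 and compound 3 would also stay together at other concentrations.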